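The source may report more compounds than this note shows. Statements on the series, on what has been measured and on what is new or still open speak of the compounds shown alone.

Compound 1 `Cc1cc(F)ccc1Nc1ncnc2cc(NC(=O)CCCCCCC(=O)NO)sc12`: 1950 nM
Compound 2 `C#Cc1cccc(Nc2ncnc3cc(NC(=O)CCCCCCC(=O)NO)sc23)c1`: 970 nM
Compound 3 `N#Cc1cccc(Nc2ncnc3cc(NC(=O)CCCCCCC(=O)NO)sc23)c1`: 1580 nM

In a functional assay on RPMI-8226 cells (Homo sapiens) for antiproliferative activity, read by radiometric assay, with a stated time of 72 h (on this read-out lower numbers stand for stronger inhibition and higher numbers for weaker inhibition), the three measured compounds cannot be told apart. Compound 3 gives 1580 nM, which lies within the scatter of both other values, as shown by a 1.2-fold lower number from compound 1 to compound 3 (0.09 log units; within the scatter) and a 1.6-fold higher number from compound 2 to compound 3 (0.21 log units; within the scatter).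

Compound 4 `COc1ccc(Nc2ncnc3cc(NC(=O)CCCCCCC(=O)NO)sc23)cc1` carries 4-methoxyphenyl in place of 3-cyanophenyl on a nitrogen on an aromatic ring. Among the measured compounds shown here, no measured step makes this exact exchange. The closest evidence comes from the other changes at that nitrogen, a 2.0-fold lower number from compound 1 to compound 2 (0.30 log units; within the scatter) and a 1.2-fold lower number from compound 1 to compound 3 (0.09 log units; within the scatter), along with a 1.6-fold higher number from compound 2 to compound 3 (0.21 log units; within the scatter). For the measured compounds named here, all of these stay within the scatter, although only three groups have been sampled. No change beyond the scatter is therefore expected in this assay, and neither direction is favoured. The expected step is a 1.1-fold lower number from compound 3 to compound 4 (0.05 log units; within the scatter). The estimated value for compound 4 is 1400 nM, with an expected range of 600 nM to 3300 nM.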

Compound 4, half-maximal inhibitory concentration: 1840 nM
Beside the measured number, compound 4's estimate is 1.3-fold (0.12 log units) below it; the measured number falls inside the stated range.
By their numbers in this assay, from the lowest: compounds 2, 3, 4 and 1 (each within the scatter of the next).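

In this assay, among the compounds shown here, the exchange at this nitrogen again produces no change that can be distinguished: 4-methoxyphenyl, the first group in the set to bring in oxygen, stays within the scatter of all three earlier groups (a 1.2-fold higher number from compound 3 to compound 4 (0.07 log units; within the scatter); a 1.9-fold higher number from compound 2 to compound 4 (0.28 log units; within the scatter); a 1.1-fold lower number from compound 1 to compound 4 (0.03 log units; within the scatter)). For the compounds shown here, all four aryl groups on this nitrogen now form a single band with no compound going against it, so replacing the nitrile-bearing 3-cyanophenyl with 4-methoxyphenyl adds a fourth group without separating any pair. No supporting measurement is available that would explain this flat result.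

The compounds shown leave open whether an amine or a carboxylic acid on the phenyl ring would shift the number beyond the scatter. They also leave open whether a saturated ring such as cyclohexyl at this nitrogen, or a longer chain elsewhere on the shared core, would do so.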